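The source may report more compounds than this note shows. Statements on the series, on what has been measured and on what is new or still open speak of the compounds shown alone.

Of the compounds shown here, three sharing one core have been measured. Compound 1 `N#Cc1cncc(OC[C@@H]2CCN2)c1` gives 0.025 nM in an assay on brain for binding affinity to Neuronal acetylcholine receptor; alpha4/beta2 (Rattus norvegicus), read by radioligand binding; on this read-out higher numbers stand for weaker inhibition and lower numbers for stronger inhibition; compound 2 `Cc1cncc(OC[C@@H]2CCN2)c1` gives 0.047 nM; compound 3 `CCCc1cncc(OC[C@@H]2CCN2)c1` gives 0.039 nM. Compound 3 stands nearest compound 2, with a 1.2-fold lower number from compound 2 to compound 3 (0.08 log units; within the scatter), and furthest from compound 1, with a 1.6-fold higher number from compound 1 to compound 3 (0.19 log units; within the scatter), so all three sit together.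

Compound 4 `NCc1cncc(OC[C@@H]2CCN2)c1` differs from compound 3 by amino in place of ethyl on a saturated chain carbon bound to an aromatic carbon. The closest guide is the step at the same chain carbon, a 1.2-fold lower number from compound 2 to compound 3 (0.08 log units; within the scatter), and the other substituent swaps on the aromatic carbon, a 1.9-fold higher number from compound 1 to compound 2 (0.27 log units; within the scatter) and a 1.6-fold higher number from compound 1 to compound 3 (0.19 log units; within the scatter), also stayed within the scatter. The expected step is therefore none beyond the scatter, a 1.0-fold higher number from compound 3 to compound 4 (0.01 log units; within the scatter). Compound 4 is estimated at 0.04 nM, ranging from 0.015 nM to 0.12 nM.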

Compound 4, inhibition constant: 4.4 nM
The estimate for compound 4 lay 110-fold (2.04 log units) below the measured number, outside the stated range (above it).
By their numbers in this assay, from the lowest: compounds 1, 3 and 2 (each within the scatter of the next); then compound 4.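

Aminomethyl is the first group at this position to move the number beyond the scatter, and higher numbers here mean weaker inhibition. Replacing propyl with it gives a 110-fold higher number from compound 3 to compound 4 (2.05 log units; beyond the scatter), replacing methyl gives a 94-fold higher number from compound 2 to compound 4 (1.97 log units; beyond the scatter), and replacing cyano gives a 180-fold higher number from compound 1 to compound 4 (2.25 log units; beyond the scatter). So this position does not accept every small group, even though cyano, methyl and propyl all sit within the scatter of one another.

As far as these compounds go, it remains open whether the loss is specific to the amine or extends to a hydroxymethyl group or a longer aminoethyl chain. No measurement here accounts for the loss.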